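A few compounds are considered here, and "the series" means these few. Any claim that something is new, unique, unknown or untested is made for them only; others in the source may bear on it.

Compound 1 `COc1ccc(-c2nc(N=C(N)N)sc2-c2ccc(OC)cc2)cc1`: in a functional assay with Oryctolagus cuniculus as the target (on this read-out lower numbers stand for stronger inhibition and higher numbers for weaker inhibition), compound 1 gives 31000 nM.
Compound 2 `CNC(=N)Nc1nc(-c2ccc(OC)cc2)c(-c2ccc(OC)cc2)s1`: in this assay compound 2 gives 62 nM.
Compound 3 `COc1ccc(-c2nc(/N=C(\N)n3ccnc3)sc2-c2ccc(OC)cc2)cc1`: for compound 3 this assay returns only a limit, > 100 nM, and no number.

Of the two numbers shown, compound 1 stands highest. Its nearest neighbour is compound 2, reached by a 500-fold lower number from compound 1 to compound 2 (2.70 log units; beyond the scatter). Toward compound 3 there is a step that the limit leaves unreadable from compound 1 to compound 3, since (the limit of > 100 nM in this assay, at which 1 of the 3 values shown sits). Between compound 2 and compound 3 the record shows an at least 1.6-fold higher number from compound 2 to compound 3 (0.20 log units; that floor lies within the scatter).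

Compound 4 `COc1ccc(-c2nc(C(=O)N3CCOCC3)sc2-c2ccc(OC)cc2)cc1` differs from compound 1 in a single place: a group of 8 heavy atoms (5 carbon, 1 nitrogen, 2 oxygen; one six-membered non-aromatic ring with 2 hetero atoms) in place of a group of 4 heavy atoms (1 carbon, 3 nitrogen; no ring), on an aromatic carbon. Among the compounds with values here, none of the measured steps exchanges the leaving group for a carbonyl-linked saturated ring, so no step bears directly on this change. Within the data shown here, the one readable step from compound 1, a 500-fold lower number from compound 1 to compound 2 (2.70 log units; beyond the scatter), shows that this position can move the number very far, but it gives no direction for a group of this kind. Compound 4 is therefore expected to stay near the weak end where compound 1 sits, with a wide band: the expected step is a 2.6-fold lower number from compound 1 to compound 4 (0.41 log units; beyond the scatter). The estimate for compound 4 in this assay is 12000 nM, with an expected range from 800 nM to 100000 nM.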

Compound 4, half-maximal inhibitory concentration: < 10 nM
Compound 4 gave a limit, no number; the forecaster's own chance of this, stated with the estimate: 25%; middle value at least 1200-fold (3.07 log units) away from the limit.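

In this assay compound 4 returns only a limit, < 10 nM, so each step to it gives a floor and not a full size. Within the data shown here, until now the only low number at this position came with a ringless group of 5 heavy atoms, whereas the (morpholin-4-yl)carbonyl group, with 0 hydrogen-bond donors in place of the 2 on the group it replaces, gives an at least 3100-fold lower number from compound 1 to compound 4 (3.49 log units; beyond the scatter). The change also goes beyond both other groups, with an at least 6.2-fold lower number from compound 2 to compound 4 (0.79 log units; beyond the scatter) and an at least 10-fold lower number from compound 3 to compound 4 (1.00 log units; beyond the scatter), so a ring at this position does not in itself give a high number, and among the two ring-bearing groups it is the one joined through a carbonyl that stands lower.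

How far the true number of compound 4 lies under this reading stays unknown: the limit of < 10 nM in this assay, at which 1 of the 4 values shown sits. The compounds shown also leave open whether the ring oxygen or the carbonyl matters, a question that a piperidin-1-ylcarbonyl group, a dimethylaminocarbonyl group or a carboxylic acid at the same place would address.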